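Quinolinyl sulfonamide swap on the ring-linked core

The compounds below may be only part of what the source reports. "The series", "measured", "known", "first", "only" and "open" are said of these compounds alone.

Of the compounds shown here, three have a number so far. Compound 1 `C=C(CC)C(=O)c1ccc(OCC(=O)NCCNS(=O)(=O)c2ccc([N+](=O)[O-])cc2)c(Cl)c1Cl` gives 580 nM in a functional assay on HL-60 cells (Homo sapiens) for cytotoxicity, read by luminescence; on this read-out higher numbers stand for weaker inhibition and lower numbers for stronger inhibition. Compound 2 `C=C(CC)C(=O)c1ccc(OCC(=O)NCCNS(=O)(=O)c2cccc3cccnc23)c(Cl)c1Cl` carries the change quinolin-8-yl in place of 4-nitrophenyl on a sulfonyl sulfur and gives 1330 nM in this assay; the step of a 2.3-fold higher number from compound 1 to compound 2 (0.36 log units; beyond the scatter). Compound 3 `C=C(CC)C(=O)c1ccc(OCC(=O)NC2CCN(S(=O)(=O)c3ccc([N+](=O)[O-])cc3)CC2)c(Cl)c1Cl` gives 2470 nM in this assay, the highest of the three numbers; against compound 2 it lies within the scatter, against compound 1 it lies beyond it. The difference between the core of compound 1 and the core of compound 3 is not broken down here.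

Compound 4 `C=C(CC)C(=O)c1ccc(OCC(=O)NC2CCN(S(=O)(=O)c3cccc4cccnc34)CC2)c(Cl)c1Cl` is not yet measured. It stands to compound 3 as compound 2 stands to compound 1: the change (quinolin-8-yl in place of 4-nitrophenyl on a sulfonyl sulfur). The place is not the same word for word, since in compound 3 the sulfonamide nitrogen is in a ring, so this is the same kind of change rather than the same change. Its one earlier occurrence, from compound 1 to compound 2, raised the number in this assay by a modest amount beyond the scatter.

For compound 4 a step of similar direction is expected, a 2.1-fold higher number from compound 3 to compound 4 (0.32 log units; beyond the scatter), resting on a 2.3-fold higher number from compound 1 to compound 2 (0.36 log units; beyond the scatter) and on the value of compound 3, 2470 nM. Compound 4 is accordingly estimated at 5200 nM in this assay, with a range from 2000 nM to 13000 nM, the width allowing that the ring-bound place may not carry the change over one to one.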

Compound 4, half-maximal inhibitory concentration: 970 nM
Estimate against measurement, compound 4: 5.4-fold (0.73 log units) above, outside the stated range (below it).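

In this assay, quinolin-8-yl in place of 4-nitrophenyl on a sulfonyl sulfur whose other neighbours are a sulfonamide nitrogen in a ring gives a 2.5-fold lower number from compound 3 to compound 4 (0.41 log units; beyond the scatter). The change therefore does not carry over from one core to the other with its direction intact, and a step read on one core is no safe guide to the same kind of change on the other: the same change on two cores in this assay, a 2.3-fold higher number (0.36 log units; beyond the scatter) from compound 1 to compound 2 and a 2.5-fold lower number (0.41 log units; beyond the scatter) from compound 3 to compound 4, 5.8-fold (0.77 log units) apart, beyond the scatter of two such steps

This shows a reversal for a single pair of groups on two cores in a single cytotoxicity read-out, with one step per core, but it does not show which feature of the two cores lies behind the reversal, nor whether either direction is typical of its core.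

Open, from the compounds shown here alone, is whether other groups on the sulfonyl sulfur, such as a plain phenyl or a 4-methoxyphenyl, would also move in opposite directions on the two cores or would follow one direction on both. Also open, going by these compounds, is how the same swap behaves on a core with a longer chain leading to the sulfonamide nitrogen, which would test whether the direction of the step depends on that nitrogen lying in a ring.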